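This account rests on a few compounds, and the source may have more. Where it says the series, first, only, none or still open, it means among the compounds named here.

Of the compounds shown here, three built on one shared core have so far been tested in a functional assay on DU-145 cells (Homo sapiens) for antiproliferative activity, read by MTT assay, with a stated time of 72 h; on this read-out higher numbers stand for weaker inhibition and lower numbers for stronger inhibition. Compound 1 `CC(C)(C)c1ccc(/C=C/C(=O)c2ccc(OCC(=O)N[C@H]3CCOC3=O)cc2)cc1` gives 6570 nM. Compound 2 `O=C(COc1ccc(C(=O)/C=C/c2ccc(Br)cc2)cc1)N[C@H]1CCOC1=O` gives 51700 nM, and compound 3 `O=C(COc1ccc(C(=O)/C=C/c2cccc([N+](=O)[O-])c2)cc1)N[C@H]1CCOC1=O` gives 41800 nM. Among these three numbers compound 3 stands second highest; its nearest neighbour is compound 2, and the gap between them, a 1.2-fold lower number from compound 2 to compound 3 (0.09 log units; within the scatter), lies within the scatter. Its furthest neighbour is compound 1, separated by a 6.4-fold higher number from compound 1 to compound 3 (0.80 log units; beyond the scatter).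

The next compound, compound 4 `O=C(COc1ccc(C(=O)/C=C/c2ccc(Cl)cc2Cl)cc1)N[C@H]1CCOC1=O`, differs from compound 3 in a single place: 2,4-dichlorophenyl in place of 3-nitrophenyl on a double-bonded chain carbon bound to a double-bonded chain carbon.

For the measured compounds named here, two measured steps bear on this exchange, since both also replace the ring on that chain carbon. The step of a 6.4-fold higher number from compound 1 to compound 3 (0.80 log units; beyond the scatter) was modest but beyond the scatter, whereas a 1.2-fold lower number from compound 2 to compound 3 (0.09 log units; within the scatter) was within it, so one ring swap of this kind moved the number clearly and another did not. A chlorine-bearing ring resembles the bromo case more than the tert-butyl case, so only a small step, if any beyond the scatter, is expected, and in the downward direction if anything: the estimate for a 1.4-fold lower number from compound 3 to compound 4 (0.14 log units; within the scatter) is small. Compound 4 is therefore expected to give about 30000 nM in this assay, within a range from 10000 nM to 90000 nM.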

Compound 4, half-maximal inhibitory concentration: 8610 nM
For compound 4 the middle estimate is 3.5-fold (0.54 log units) above the measured one; the measured number lies below the stated range.
By their numbers in this assay, from the lowest: compounds 1 and 4 (each within the scatter of the next); then compounds 3 and 2 (each within the scatter of the next).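

In this assay, the ring on this chain carbon can shift the number clearly even when the bromo and nitro rings gave no separation: 2,4-dichlorophenyl brings (a 4.9-fold lower number from compound 3 to compound 4 (0.69 log units; beyond the scatter)) and (a 6.0-fold lower number from compound 2 to compound 4 (0.78 log units; beyond the scatter)), both beyond the scatter. The step to the tert-butyl compound (a 1.3-fold higher number from compound 1 to compound 4 (0.12 log units; within the scatter)) lies within the scatter, so the lower level seen so far is not tied to a 4-(tert-butyl)phenyl ring. Nor does carrying a halogen decide the matter among these four compounds, as compound 2 with its 4-bromophenyl ring stays within the scatter of the 3-nitrophenyl compound 3, while compound 4 with its two chlorines stays within the scatter of compound 1.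

No measurement at hand explains why these rings separate as they do. As far as these compounds go, it also remains open whether a phenyl ring with a single chlorine, or one with an amine in place of the chlorines, would stay at the level of compound 4 or return to that of compound 2.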